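The compounds below may be only part of what the source reports. "The series", "measured", "known", "first", "only" and "open" are said of these compounds alone.

Measured in an ADME assay on MT2 cells (Homo sapiens) for cytotoxicity, read by XTT assay, with a stated time of 4 days; on this read-out higher numbers stand for lower toxicity in this test and lower numbers for higher toxicity in this test:
- compound 1 `Cc1nc(C(NC(=O)C(=O)Nc2ccc(F)c(F)c2)C2CCCCN2)sc1CO`: > 87000 nM, a limit
- compound 2 `Cc1nc(C(NC(=O)C(=O)Nc2ccc(F)cc2)C2CCCCN2)sc1CO`: > 113000 nM, a limit

Compound 2 has no exact position on the scale, since its result in this assay is only the limit > 113000 nM. Compound 3 `Cc1nc(C(NC(=O)C(=O)NC2CCCCCC2)C2CCCCN2)sc1CO` is the next to be tested, and it changes the group on the amide-type nitrogen: cycloheptyl in place of 4-fluorophenyl on an amide-type nitrogen. Among the measured compounds shown here, the only measured step is a step that the two limits leave unreadable from compound 1 to compound 2. It concerns a fluoro group on the aromatic ring, not cycloheptyl in place of 4-fluorophenyl, so it offers no size to carry over. With no measured guide, no step beyond the scatter is expected in this assay, and no direction is predicted. The expected step is an at least 1.1-fold lower number from compound 2 to compound 3 (0.05 log units; that floor lies within the scatter). For compound 3 the estimate is 100000 nM, with an expected range from 40000 nM to 200000 nM.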

Compound 3, half-maximal cytotoxic concentration: > 90000 nM
Compound 3 ended at the assay's limit; the forecaster's own chance of this, stated with the estimate: 65%; the middle value does not contradict the limit.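

Among the compounds shown here, no step among compound 1, compound 2 and compound 3 can be read in this assay, as each result is a limit and not a number. The compounds shown leave open whether exchanging 4-fluorophenyl for cycloheptyl, or removing a fluoro group, changes this read-out at all.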